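The source may hold more compounds than are shown below. What is called first, only, known or untested is meant among the compounds shown, and "the series" means these compounds.

Working notes on a small urea series built on one shared core.

Compound 1 `COC(=O)c1ccc(NC(=O)Nc2cc(C)nc3ccccc23)cc1` in an ADME assay on Raji cells (Homo sapiens) for cytotoxicity, with a stated time of 72 h (on this read-out higher numbers stand for an effect only at larger amounts of compound and lower numbers for an effect already at smaller amounts), gives 17000 nM. Compound 2 `Cc1cc(NC(=O)Nc2ccc(C(F)(F)F)cc2)c2ccccc2n1` gives 23000 nM in this assay. Compound 3 `COC(=O)c1cccc(NC(=O)Nc2cc(C)nc3ccccc23)c1` gives 26000 nM in this assay. Compound 1 and compound 3 have the same atoms joined differently; the difference between the two cores is not broken down here, and their two values lie within the scatter of each other.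

From compound 1 to compound 2 the change is trifluoromethyl in place of methoxycarbonyl on an aromatic carbon, with a step of a 1.4-fold higher number from compound 1 to compound 2 (0.13 log units; within the scatter).

Compound 4 `Cc1cc(NC(=O)Nc2cccc(C(F)(F)F)c2)c2ccccc2n1` is not yet measured. It differs from compound 3 by trifluoromethyl in place of methoxycarbonyl on an aromatic carbon. This is the same kind of change as that from compound 1 to compound 2, but not the same: there the entering group sits para to a large group, here meta to a large group.

Among the compounds with values here, for compound 4 the expected step is a 1.3-fold higher number from compound 3 to compound 4 (0.12 log units; within the scatter), a size taken from the measured 1.4-fold higher number from compound 1 to compound 2 (0.13 log units; within the scatter), on the view that the same kind of change gives a step of like size, with the caveat that only one such pair exists. Compound 4 is thus estimated at 34000 nM, expected between 17000 nM and 70000 nM.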

Compound 4, half-maximal effective concentration: 10000 nM
Compound 4: middle estimate off by 3.4-fold (0.53 log units), on the high side; the whole stated range lies above it.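

In this assay trifluoromethyl in place of methoxycarbonyl on the core of compound 3 gives a 2.6-fold lower number from compound 3 to compound 4 (0.41 log units; beyond the scatter) and this modest step lies beyond the scatter. The same change therefore does not carry from one core to the other with a common size or direction in this read-out: the same change on two cores in this assay, a 1.4-fold higher number (0.13 log units; within the scatter) from compound 1 to compound 2 and a 2.6-fold lower number (0.41 log units; beyond the scatter) from compound 3 to compound 4, 3.5-fold (0.55 log units) apart, beyond the scatter of two such steps. Within the data shown here, with only two such pairs, this shows that the step measured on one core was a poor guide to the step on the other, but it does not show what sets the two cores apart, and it yields no rule for any further core.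

Among these compounds, it remains open whether an amine, a carboxylic acid or a nitrile entering at the same place would give a step like the one to compound 2 or the one to compound 4. Also open, as far as these compounds go, is whether a third pair carrying this same change would side with either of the two steps or give a different result again.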